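Octyl for phenyl on the ring-nitrogen acyl group

The source may report more compounds than this note shows. Statements on the series, on what has been measured and on what is new or still open speak of the compounds shown alone.

The series shares one core, carried into a functional assay on NCI-H23 cells (Homo sapiens) for cytotoxicity, read by sulforhodamine B assay, with a stated time of 72 h (a lower number here means a stronger inhibitor of growth, a higher number a weaker inhibitor of growth), on three compounds. Compound 2 `O=C(Nc1ccccc1O)C1CCc2ccccc2N1` gives 2230 nM. Compound 3 `O=C(Nc1ccccc1O)C1CCc2ccccc2N1C(=O)c1ccccc1` gives 3490 nM. Compound 1 `CCCCCCCCC(=O)N1c2ccccc2CCC1C(=O)Nc1ccccc1C(F)(F)F` gives 4220 nM. On these numbers compound 3 stands second highest of three, nearest to compound 1 and furthest from compound 2, and both gaps are within the scatter.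

For the measured compounds named here, the only single-point step measured so far is a 1.6-fold higher number from compound 2 to compound 3 (0.19 log units; within the scatter), so putting an acyl group on the ring nitrogen did not move the number beyond the scatter.

Compound 4 `CCCCCCCCC(=O)N1c2ccccc2CCC1C(=O)Nc1ccccc1O` is to be measured next. It differs from compound 3 by octyl in place of phenyl on a carbonyl carbon. Going by the values given here, no measured step covers this exchange directly; compound 1 carries the octylcarbonyl group but differs from compound 4 on the aniline ring, so it shows only that a compound with octylcarbonyl on this nitrogen sits near compound 3 in this assay. Among the compounds with values here, the one acyl step, from hydrogen to benzoyl, was within the scatter. Compound 4 is therefore expected to change little, an estimated 1.1-fold higher number from compound 3 to compound 4 (0.06 log units; within the scatter), with the number expected at about 4000 nM in a range from 1600 nM to 10000 nM.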

Compound 4, concentration for 50% growth inhibition: 55800 nM
Estimate against measurement, compound 4: 14-fold (1.14 log units) below, and the stated range ends below it.
By their numbers in this assay, from the lowest: compounds 2, 3 and 1 (each within the scatter of the next); then compound 4.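

In this assay the group on a carbonyl carbon matters: octyl in place of phenyl gives a 16-fold higher number from compound 3 to compound 4 (1.20 log units; beyond the scatter), whereas benzoyl in place of hydrogen on a nitrogen on an aromatic ring in a ring gave only a 1.6-fold higher number from compound 2 to compound 3 (0.19 log units; within the scatter). Octylcarbonyl in place of hydrogen at that same nitrogen gives a 25-fold higher number from compound 2 to compound 4 (1.40 log units; beyond the scatter), so the presence of an acyl group alone does not set the number, and compound 3 goes against any rule that acylation raises it. With octylcarbonyl held constant, hydroxy in place of trifluoromethyl on an aromatic carbon gives a 13-fold higher number from compound 1 to compound 4 (1.12 log units; beyond the scatter), so the number also depends on that substituent on the aniline ring.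

The compounds shown leave open whether the rise follows the length of the chain or the loss of the aromatic ring, a question that a butanoyl or a cyclohexylcarbonyl group on the same nitrogen would help to separate. No measurement in hand bears on the reason for these steps.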